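Terminal amine on the butylsulfanyl chain of the series

This account rests on a few compounds, and the source may have more. Where it says the series, first, only, none or still open, it means among the compounds named here.

Three compounds of one series share a core and differ only in the substituent on an aromatic carbon. Compound 1 `CCCOc1nc(C(C)(C)C)ccc1CNC(=O)C(C)c1ccc(NS(C)(=O)=O)c(F)c1` gives 1.7 nM in an assay on cells for antagonist activity at transient receptor potential cation channel subfamily V member 1 (Homo sapiens), read by FLIPR and calcium flux, with a stated time of 6 min; on this read-out lower numbers stand for stronger inhibition and higher numbers for weaker inhibition. Compound 2 `CC(C(=O)NCc1ccc(C(C)(C)C)nc1OC1CCCCC1)c1ccc(NS(C)(=O)=O)c(F)c1` gives 2.5 nM in this assay, and compound 3 `CCCCSc1nc(C(C)(C)C)ccc1CNC(=O)C(C)c1ccc(NS(C)(=O)=O)c(F)c1` gives 3.2 nM. Compound 3 holds the highest of the three numbers, yet its distance to the others stays within the scatter: a 1.9-fold higher number from compound 1 to compound 3 (0.27 log units; within the scatter) and a 1.3-fold higher number from compound 2 to compound 3 (0.11 log units; within the scatter). For the measured compounds named here, the remaining step, a 1.5-fold higher number from compound 1 to compound 2 (0.17 log units; within the scatter), is likewise within the scatter, so nothing among the measured pairs separates these substituents.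

Compound 4 `CC(C(=O)NCc1ccc(C(C)(C)C)nc1SCCCN(C)C)c1ccc(NS(C)(=O)=O)c(F)c1` departs from compound 3 by dimethylamino in place of methyl on a saturated chain carbon, three bonds along the chain from a sulfur. Going by the values given here, no measured step alters the end of this chain, so the only bearing comes from the steps at the same aromatic carbon, all of them within the scatter. On that basis compound 4 is expected to stay close to compound 3, with a 1.3-fold higher number from compound 3 to compound 4 (0.10 log units; within the scatter) in this assay carrying no direction beyond the scatter. The estimate for compound 4 is 4 nM, between 1.3 nM and 12 nM.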

Compound 4, inhibition constant: 51.8 nM
Compound 4: middle estimate off by 13-fold (1.11 log units), on the low side, and the stated range ends below it.
By their numbers in this assay, from the lowest: compounds 1, 2 and 3 (each within the scatter of the next); then compound 4.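

In this assay, for the compounds shown here, this position, which showed no separation among propoxy, cyclohexyloxy and butylsulfanyl, does respond to a change at the chain end: dimethylamino in place of methyl gives a 16-fold higher number from compound 3 to compound 4 (1.21 log units; beyond the scatter) and is the first step beyond the scatter. Compound 4 stands equally clear of the two oxygen-linked compounds, with a 21-fold higher number from compound 2 to compound 4 (1.32 log units; beyond the scatter) and a 30-fold higher number from compound 1 to compound 4 (1.48 log units; beyond the scatter), so the 3-(dimethylamino)propyl sulfanyl substituent is the only one shown that sets a compound apart from the rest. Nothing at hand accounts for this step.

From the compounds shown here alone, what a primary amine, a terminal hydroxyl or a carboxylic acid at the same chain end would give remains open. Also open, going by these compounds, is how a shorter or longer chain carrying dimethylamino would read, and whether the same group on a propoxy chain would give a similar step.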